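Hydroxyethyl added to the far ring of compound 2

The source may report more compounds than this note shows. Statements on the series, on what has been measured and on what is new or still open speak of the compounds shown alone.

In a functional assay on blood for antagonist activity at thromboxane A2 receptor (Homo sapiens) (a higher number here means weaker binding, a lower number tighter binding), compound 1 `O=C(O)CC/C=C\CO[C@H]1[C@@H](OCc2ccc(-c3ccccc3)cc2)CC[C@@H]1N1CCCCC1` gives 10 nM; 7.94 nM (2 entries), and compound 3 `O=C(O)CC/C=C\CO[C@H]1C(OCc2ccc(-c3ccccc3)cc2)CC[C@@H]1N1CCCCC1` gives 63.1 nM; 15.9 nM (2 entries); the repeated values of both (the several entries of compound 1 in this assay, 10 nM; 7.94 nM (2 entries), (the several entries of compound 3 in this assay, 63.1 nM; 15.9 nM (2 entries))) overlap, and the two compounds differ in drawing only through (the fact that one of compounds 1 and 3 is drawn with a defined configuration and the other without, at the place where they differ). Compound 2 `O=C(O)CC/C=C\CO[C@H]1C(OCc2ccc(-c3ccccc3)cc2)CC[C@@H]1N1CCCCCC1` gives 12.6 nM in this assay; it carries the only single number shown for it, two further entries giving no number, and it lies in the same range as compounds 1 and 3.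

Compound 4 `O=C(O)CC/C=C\CO[C@H]1C(OCc2ccc(-c3ccccc3CCO)cc2)CC[C@@H]1N1CCCCCC1` differs from compound 2 by 2-hydroxyethyl in place of hydrogen on an aromatic carbon. Within the data shown here, no measured pair carries this change, so in this assay no step beyond the usual scatter is expected in either direction. The expected step is a 1.3-fold higher number from compound 2 to compound 4 (0.10 log units; within the scatter). Compound 4 is estimated at 16 nM, with a range from 4 nM to 60 nM.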

Compound 4, dissociation constant: 2 nM
Compound 4: middle estimate off by 8.0-fold (0.90 log units), on the high side, and the stated range ends above it.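

In this assay, 2-hydroxyethyl in place of hydrogen on an aromatic carbon, ortho to a large group, gives a 6.3-fold lower number from compound 2 to compound 4 (0.80 log units; beyond the scatter) and so marks this position as one where a substitution can move the number. Compounds 1, 2 and 3 all carry hydrogen here, so they gave no reading of this position. Nothing at hand bears on the origin of this step, which rests on a single pair.

Going by these compounds, whether an ethyl chain, a longer alcohol chain, an amine or a carboxylic acid at the same carbon gives a similar step remains open. Also open, on these data alone, is whether 2-hydroxyethyl has the same effect on the core of compound 1.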